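The source may report more compounds than this note shows. Statements on the series, on what has been measured and on what is new or still open speak of the compounds shown alone.

In a functional assay (lung) for inhibition, with Cavia porcellus as the target (on this read-out lower numbers stand for stronger inhibition and higher numbers for weaker inhibition), compound 1 `O=C(O)CC1CCCC1Cc1ccc(OCc2ccc3ccccc3n2)cc1` gives 90 nM. Compound 2 `CC(CCc1nnn[nH]1)Cc1ccc(OCc2ccc3ccccc3n2)cc1` gives 27 nM in this assay, and compound 3 `c1cc(CCCCc2nnn[nH]2)cc(OCc2ccc3ccccc3n2)c1` gives 105 nM. Among these three numbers compound 2 stands lowest, with compound 1 nearest and compound 3 furthest from it. For the measured compounds named here, the only single-point step between measured compounds is a 3.3-fold lower number from compound 1 to compound 2 (0.52 log units; beyond the scatter), which replaces the whole acid-bearing side chain; compound 3 differs from compound 2 in more than one place, so only its value can be set beside that of compound 2.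

Compound 4 `c1ccc(C(CCc2nnn[nH]2)Cc2ccc(OCc3ccc4ccccc4n3)cc2)cc1` is the next compound to be measured. It differs from compound 2 as follows: phenyl in place of methyl on a saturated chain carbon bound to two saturated chain carbons. Going by the values given here, no measured step bears on this change: the one step in hand, a 3.3-fold lower number from compound 1 to compound 2 (0.52 log units; beyond the scatter), exchanges a different group at a different place, and nothing among the measured compounds tests a phenyl against a methyl on a saturated chain carbon bound to two saturated chain carbons. The expectation is therefore a step that stays within the scatter or barely beyond it, in either direction. For compound 4 the estimate in this assay is 35 nM, with a range from 10 nM to 120 nM. This estimate corresponds to an expected step of a 1.3-fold higher number from compound 2 to compound 4 (0.11 log units; within the scatter).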

Compound 4, half-maximal inhibitory concentration: 14 nM
Estimate against measurement, compound 4: 2.5-fold (0.40 log units) above; low and high end bracket the measured number.
By their numbers in this assay, from the lowest: compounds 4 and 2 (each within the scatter of the next); then compounds 1 and 3 (each within the scatter of the next).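

The phenyl in place of methyl on a saturated chain carbon bound to two saturated chain carbons gives, in this assay, a 1.9-fold lower number from compound 2 to compound 4 (0.29 log units; within the scatter), so the read-out does not separate the two groups. Before compound 4, this carbon had been seen with only the methyl of compound 2, so it was unknown whether a larger group could stand there; the result shows that one six-membered aromatic ring of carbon only can enter at this place without a step beyond the scatter. No measured evidence accounts for this outcome, and the pair alone cannot show what the phenyl does here.

The compounds shown leave open how far this place accepts other groups, such as ethyl, benzyl, cyclohexyl or an amine-bearing chain, since a methyl and a phenyl are the only two groups compared on this carbon. They also leave open whether a plain hydrogen at this place would give a number in line with those of compound 2 and compound 4, and whether a pyridyl ring would behave as the phenyl does.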